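The source may report more compounds than this note shows. Statements on the series, on what has been measured and on what is new or still open speak of the compounds shown alone.

Within the data shown here, in a functional assay on MIA PaCa-2 cells (Homo sapiens) for cytotoxicity, read by MTT assay, with a stated time of 4 h (on this read-out lower numbers stand for stronger inhibition and higher numbers for weaker inhibition), compound 2 (`COC1=CC(=O)c2c(COc3ccc(F)cc3F)c(C)n(C)c2C1=O`) gives 255 nM and compound 1 (`COC1=CC(=O)c2c(COc3ccc(C#N)cc3)c(C)n(C)c2C1=O`) gives 463 nM and the two stand level, with a 1.8-fold lower number from compound 1 to compound 2 (0.26 log units; within the scatter) as the only measured step. Compound 3 (`COC1=CC(=O)c2c(COc3ccncc3)c(C)n(C)c2C1=O`) carries pyridin-4-yl in place of 2,4-difluorophenyl on an oxygen on a saturated carbon. Among the measured compounds shown here, the one measured step was made at this same place and is the sole guide. No ring with a hetero atom has been measured there. The expected step in this assay is a 1.5-fold higher number from compound 2 to compound 3 (0.17 log units; within the scatter) and none beyond the scatter is foreseen. Compound 3 is estimated at 380 nM (expected range 140 nM to 1000 nM).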

Compound 3, half-maximal inhibitory concentration: 2560 nM
Beside the measured number, compound 3's estimate is 6.7-fold (0.83 log units) below it, and the stated range ends below it.
By their numbers in this assay, from the lowest: compounds 2 and 1 (each within the scatter of the next); then compound 3.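

In this assay, the group on the oxygen on a saturated carbon proves able to move the number beyond the scatter, which the earlier pair of compounds did not show. Pyridin-4-yl gives a 10-fold higher number from compound 2 to compound 3 (1.00 log units; beyond the scatter) and a 5.5-fold higher number from compound 1 to compound 3 (0.74 log units; beyond the scatter), so a ring with a hetero atom separates from both rings of carbon only. Nothing available bears on the reason for this shift. Open, going by these compounds, is whether the ring nitrogen or the loss of the fluorine or nitrile substituents governs the change. Unsubstituted phenyl and pyridin-3-yl would separate these readings.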